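Swapping an aryl amide for a cyclopropyl amide

This account rests on a few compounds, and the source may have more. Where it says the series, first, only, none or still open, it means among the compounds named here.

Compound 3 `COc1ccc(NC(=O)c2cc(Oc3ccc(/C=C/c4ccncc4)cc3)ccn2)cc1` gives 25600 nM in a functional assay on A549 cells (Homo sapiens) for antiproliferative activity, read by CCK-8 assay, with a stated time of 48 h (on this read-out higher numbers stand for weaker inhibition and lower numbers for stronger inhibition), the highest of the three numbers in hand, though within the usual scatter of compound 2 `COc1ccc(NC(=O)c2cc(Oc3ccc(/C=C/c4ccccn4)cc3)ccn2)cc1` at 20000 nM and of compound 1 `O=C(Nc1ccccc1)c1cc(Oc2ccc(/C=C/c3ccccn3)cc2)ccn1` at 19100 nM. Compound 4 `O=C(NC1CC1)c1cc(Oc2ccc(/C=C/c3ccncc3)cc2)ccn1` differs from compound 3 by cyclopropyl in place of 4-methoxyphenyl on an amide-type nitrogen. For the measured compounds named here, no measured step touches the amide nitrogen: a 1.0-fold higher number from compound 1 to compound 2 (0.02 log units; within the scatter) only adds a methoxy to the aromatic ring, and a 1.3-fold higher number from compound 2 to compound 3 (0.11 log units; within the scatter) concerns the pyridyl end. The present change removes the whole aromatic ring, so the data give no direct guide. Compound 4 is therefore expected to stay near compound 3, with wide uncertainty, an estimated step of a 1.2-fold higher number from compound 3 to compound 4 (0.07 log units; within the scatter). Compound 4 is estimated at 30000 nM, between 8000 nM and 110000 nM.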

Compound 4, half-maximal inhibitory concentration: 35500 nM
For compound 4 the middle estimate is 1.2-fold (0.07 log units) below the measured one; low and high end bracket the measured number.
By their numbers in this assay, from the lowest: compounds 1, 2, 3 and 4 (each within the scatter of the next).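

For the compounds shown here, the amide nitrogen is changed here for the first time, and the step is a 1.4-fold higher number from compound 3 to compound 4 (0.14 log units; within the scatter) in this assay. For this pair, a 4-methoxyphenyl group of 8 heavy atoms can give way to a cyclopropyl group of 3 heavy atoms, losing the aromatic ring, with no change beyond the scatter. Nothing measured here offers an explanation for this.

From the compounds shown here alone, whether a basic amine such as piperidine, a carboxylic acid or a longer alkyl chain on this nitrogen would move the number beyond the scatter remains open.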